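Thiophene isomer swap at the enone carbonyl of the hydroxamates

This account rests on a few compounds, and the source may have more. Where it says the series, first, only, none or still open, it means among the compounds named here.

Notes on the series. Compound 1 `COc1cccc(C(=O)/C=C/c2cc(/C=C/C(=O)NO)n(C)c2)c1` carries 3-methoxyphenyl on the carbonyl carbon of the enone arm; in an assay on isolated protein for inhibition of histone deacetylase HD1B (Zea mays) (on this read-out lower numbers stand for stronger inhibition and higher numbers for weaker inhibition), compound 1 gives 600 nM. Compound 2 `Cn1cc(/C=C/C(=O)c2cccs2)cc1/C=C/C(=O)NO` has thiophen-2-yl in that position, and in this assay compound 2 gives 25800 nM. Among the compounds with values here, the only step measured so far runs between these two: a 43-fold higher number from compound 1 to compound 2 (1.63 log units; beyond the scatter). Among the two numbers available, compound 2 stands highest, with compound 1 as its nearest neighbour at a markedly lower number.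

Compound 3 `Cn1cc(/C=C/C(=O)c2ccsc2)cc1/C=C/C(=O)NO` keeps every atom of compound 2 and differs only in how the ring is attached: thiophen-3-yl in place of thiophen-2-yl on a carbonyl carbon. Within the data shown here, no measured step bears on this change; the one step in hand exchanges a whole aryl group rather than the attachment point of the same ring, and it gives no guidance on direction. The expectation is therefore a step of modest size, if any, with compound 3 estimated at 12000 nM and a range from 2500 nM to 60000 nM. Relative to compound 2 the estimated step is a 2.2-fold lower number from compound 2 to compound 3 (0.33 log units; beyond the scatter).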

Compound 3, half-maximal inhibitory concentration: 22600 nM
Estimate against measurement, compound 3: 1.9-fold (0.27 log units) below; the range from low to high includes it.
By their numbers in this assay, from the lowest: compound 1; then compounds 3 and 2 (each within the scatter of the next).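

In this assay the change of attachment point, thiophen-3-yl in place of thiophen-2-yl on a carbonyl carbon, gives a 1.1-fold lower number from compound 2 to compound 3 (0.06 log units; within the scatter) and so does not separate the two thiophene isomers at this position. Thiophen-3-yl in place of 3-methoxyphenyl gives a 38-fold higher number from compound 1 to compound 3 (1.58 log units; beyond the scatter) as a large step, so the distance from compound 1 first seen with thiophen-2-yl is not tied to that one attachment and holds for both isomers. Nothing available speaks to what lies behind these numbers.

With 3-methoxyphenyl the only aryl group standing apart, the compounds shown do not tell whether the lower number of compound 1 goes with the phenyl ring itself or with the methoxy group on it, a question that a plain phenyl on the same carbonyl carbon would address. Going by these compounds, how a pyridine ring, or a thiophene ring carrying a methoxy group, would read at this position in this assay also remains open.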